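Removing the isopropyl side chain in the nitroimidazolyl ester series

The compounds below may be only part of what the source reports. "The series", "measured", "known", "first", "only" and "open" are said of these compounds alone.

Within the data shown here, compound 3 `Cc1ncc([N+](=O)[O-])n1CCOC(=O)c1cc(NC(=O)[C@@H](NC(=O)OCc2ccccc2)C(C)C)ccc1O` gives the highest number of the three measured members in a functional assay on the whole organism (strain Wistar) for inhibition, with Rattus norvegicus as the target, read by paw edema, with stated times of 1 h and 24 h, at a dose of 10 mg/kg by the intraperitoneal route; on this read-out higher numbers stand for more inhibition at the one dose given (going by the name of the read-out) and lower numbers for less inhibition: compound 3 gives 51.7%. Compound 2 `Cc1ncc([N+](=O)[O-])n1CCOC(=O)c1cc(NC(=O)[C@H](C)NC(=O)OCc2ccccc2)ccc1O` gives 11.6% in this assay, and compound 1 `CC(=O)Nc1ccc(O)c(C(=O)OCCn2c([N+](=O)[O-])cnc2C)c1`, which carries the acetamide in place of the carbamate-protected amino acid, gives 0%.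

Compound 4 `Cc1ncc([N+](=O)[O-])n1CCOC(=O)c1cc(NC(=O)CNC(=O)OCc2ccccc2)ccc1O` has not been measured. Its change from compound 3 is hydrogen in place of isopropyl on a saturated chain carbon bound to an amide-type nitrogen and a carbonyl carbon. Among the measured compounds shown here, the one measured step that bears on this position is a number 40.1 percentage points higher from compound 2 to compound 3 (beyond the scatter), where the larger isopropyl was worth a large gain over methyl. For the measured compounds named here, compound 4 goes the other way, past methyl to hydrogen, and the values of compound 2 and compound 1 show that the smaller the group at this position, the lower the inhibition found so far, with no compound going against this among the three. A drop beyond the scatter is therefore expected, of size a number 46.7 percentage points lower from compound 3 to compound 4 (beyond the scatter). Compound 4 is estimated at 5% in this assay, with a range from 0% to 20%.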

Compound 4, a percentage reported as inhibition, in the whole organism at one dose (the size of the read-out at that dose, not a potency): 17.1%
Estimate against measurement, compound 4: 12.1 percentage points below; the range from low to high includes it.
By their numbers in this assay, from the lowest: compound 1; then compounds 2 and 4 (each within the scatter of the next); then compound 3.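

In this assay, taking away the isopropyl loses most of what it gained over methyl (a number 34.6 percentage points lower from compound 3 to compound 4 (beyond the scatter)), whereas hydrogen and methyl on this carbon cannot be told apart (a number 5.5 percentage points higher from compound 2 to compound 4 (within the scatter)). The high number among these compounds therefore goes with isopropyl alone, and no graded trend with group size runs through hydrogen and methyl. With hydrogen on this carbon, the (benzyloxycarbonyl)amino in place of hydrogen on a saturated chain carbon bound to a carbonyl carbon still gives a modest step (a number 17.1 percentage points higher from compound 1 to compound 4 (beyond the scatter)), so that group counts for something without any side chain. Nothing available explains the isopropyl effect.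

Still open, on these data alone, is whether a longer chain, such as isobutyl, or a benzyl group would match or exceed isopropyl on this carbon. A side chain bearing an amine or a carboxylic acid also remains untested among the compounds shown.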